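The compounds below may be only part of what the source reports. "The series", "measured", "known", "first", "only" and "open" are said of these compounds alone.

Measured so far:
compound 1, `O=C(CN(c1nc(Cl)nc2[nH]cnc12)C1CC1)NCC(=O)OCc1ccccc1` — 18.7%
compound 2, `N=C(N)NCCC[C@H](NC(=O)CN(c1nc(Cl)nc2[nH]cnc12)C1CC1)C(=O)OCc1ccccc1` — 23.2%

Both numbers come from a functional assay on the whole organism (Tail, strain ICR) with Mus musculus as the target, in the tail flick test, with a stated time of 30 min, at a dose of 25 umol/kg by the oral route; on this read-out higher numbers stand for a stronger effect at the one dose given and lower numbers for a weaker effect. Compound 2 stands alongside compound 1 rather than apart from it: the step of a number 4.5 percentage points higher from compound 1 to compound 2 (within the scatter) is within the scatter, so the two cannot be told apart on these numbers.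

Compound 3, `CC[C@H](C)[C@H](NC(=O)CN(c1nc(Cl)nc2[nH]cnc12)C1CC1)C(=O)OCc1ccccc1`, differs from compound 2 in one place: a group of 4 heavy atoms (4 carbon; no ring) in place of a group of 7 heavy atoms (4 carbon, 3 nitrogen; no ring), on a saturated chain carbon bound to an amide-type nitrogen and a carbonyl carbon. Going by the values given here, only one measured step bears on this change, the one in which a hydrogen was exchanged for the very group that now leaves, a number 4.5 percentage points higher from compound 1 to compound 2 (within the scatter), and it was small. As far as these compounds go, nothing has been measured for sec-butyl in this place, so its own contribution is unknown. The step of a number 3.2 percentage points lower from compound 2 to compound 3 (within the scatter) is thus expected to stay within the scatter, in line with the small step of a number 4.5 percentage points higher from compound 1 to compound 2 (within the scatter), with no clear direction. Compound 3 is estimated at 20%, within a range from 8% to 33%.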

Compound 3, a percentage reported as activity, at one dose (the size of the read-out at that dose, not a potency): 41.4%
For compound 3 the middle estimate is 21.4 percentage points below the measured one; the measured number lies above the stated range.
By their numbers in this assay, from the lowest: compounds 1 and 2 (each within the scatter of the next); then compound 3.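

Changing the group on this saturated chain carbon, bound to an amide-type nitrogen and a carbonyl carbon, can clearly shift the read-out in this assay: the printed steps are a number 18.2 percentage points higher from compound 2 to compound 3 (beyond the scatter) and a number 22.7 percentage points higher from compound 1 to compound 3 (beyond the scatter). Going by these compounds alone, the one earlier step at this place stayed within the scatter, so it left open whether this place mattered at all; now sec-butyl stands apart from both hydrogen and the nitrogen-bearing group it replaces, which shows that the identity of the group counts, not merely the presence of one. No measurement at hand explains why compound 3 gives the higher number.

As far as these compounds go, whether a shorter chain such as methyl or a longer one such as n-hexyl would give a similar number remains open. So does the outcome with a carboxylic acid or a phenyl ring in this place.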